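Compound 3: what a plain phenyl may cost

The source may report more compounds than this note shows. Statements on the series, on what has been measured and on what is new or still open speak of the compounds shown alone.

Measured in a functional assay on A549 cells (Homo sapiens) for antiproliferative activity, read by MTT assay, with a stated time of 72 h; on this read-out higher numbers stand for weaker inhibition and lower numbers for stronger inhibition:
- Compound 1 `COc1cc(-n2cnc3ccc(-c4ccccc4Cl)cc32)cc(OC)c1OC` gives > 10000 nM as a limit of the assay
- Compound 2 `COc1ccc(-c2ccc3ncn(-c4cc(OC)c(OC)c(OC)c4)c3c2)cc1O` gives 200 nM as a number

Of these two compounds, only compound 2 has an actual number, 200 nM, so it has no measured neighbour to be ranked against precisely. Compound 3 `COc1cc(-n2cnc3ccc(-c4ccccc4)cc32)cc(OC)c1OC` is still unmeasured. It keeps the core of compound 2 and carries phenyl in place of 3-hydroxy-4-methoxyphenyl on an aromatic carbon.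

For the measured compounds named here, one measured step bears on this change: an at least 50-fold lower number from compound 1 to compound 2 (1.69 log units; beyond the scatter), which is large and rests on a limit. It is a single step, and it involves 2-chlorophenyl rather than phenyl, so it guides only the direction and the rough size. Compound 3 gives up the group that compound 2 gained in that step, so a large step to a higher number is expected in this assay. The estimated change is a 15-fold higher number from compound 2 to compound 3 (1.18 log units; beyond the scatter) in that direction. For compound 3 the expected value is 3000 nM, with an estimated range from 600 nM to 15000 nM as its likely span.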

Compound 3, half-maximal inhibitory concentration: 3060 nM
Compound 3: the middle estimate sits 1.0-fold (0.01 log units) below what was measured, and the stated range covers the measured number.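

In this assay, plain phenyl can now be set directly against the 3-hydroxy-4-methoxyphenyl group on this aromatic carbon. The change gives a 15-fold higher number from compound 2 to compound 3 (1.18 log units; beyond the scatter), so a large gap remains with no chloro in play. The chloro also counts for something: hydrogen in its place gives an at least 3.2-fold lower number from compound 1 to compound 3 (0.51 log units; beyond the scatter), and the earlier large step therefore splits into two parts, each beyond the scatter. Compound 1 stands at a limit of the assay, so the share of the chloro stays a minimum: the limit of > 10000 nM in this assay, at which 1 of the 3 values shown sits.

The compounds shown do not tell whether the hydroxy or the methoxy carries the gain, as both leave together, and a ring carrying only one of them would be needed to separate the two. They also leave open how this position responds to a group of another kind, such as an amine or a carboxylic acid on the ring.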